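The source may report more compounds than this note shows. Statements on the series, on what has been measured and on what is new or still open speak of the compounds shown alone.

Measured compounds in an ADME assay on HepG2 cells (Homo sapiens) for inhibition, with a stated time of 72 h; a higher number here means that more compound is needed for the effect, a lower number that less compound is needed:

compound 1, `C=CC(=O)Nc1cccc(-c2nc3ccccc3s2)c1`: > 25000 nM.
compound 2, `C/C=C/C(=O)Nc1cccc(-c2nc3ccccc3s2)c1`: > 25000 nM.
compound 3, `CN(C)CCC(=O)Nc1cccc(-c2nc3ccccc3s2)c1`: 21000 nM.

For compound 1 the value given is a limit of the assay, not a number. The same holds for compound 2, whose value is likewise a limit. Both sit at the limit of > 25000 nM in this assay, at which 2 of the 3 values shown sit. Among the compounds with values here, compound 3 is therefore the only compound of the three with a measured number, and it stands alone as the single point of reference. The step of an at least 1.1-fold lower number from compound 1 to compound 3 (0.07 log units; that floor lies within the scatter) and the step of an at least 1.1-fold lower number from compound 2 to compound 3 (0.07 log units; that floor lies within the scatter) are both read only as floors, and those floors lie within the scatter; the step that the two limits leave unreadable from compound 1 to compound 2 cannot be read at all.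

Compound 4, `O=C(CCl)Nc1cccc(-c2nc3ccccc3s2)c1`, differs from compound 3 by chloro in place of (dimethylamino)methyl on a saturated chain carbon bound to a carbonyl carbon. Within the data shown here, no measured step touches this change directly, and the steps that were measured on the same side of the carbonyl were all small. The expected step of a 2.6-fold lower number from compound 3 to compound 4 (0.42 log units; beyond the scatter) in this assay thus rests on little. Compound 4 is estimated at 8000 nM, expected to fall between 1500 nM and 30000 nM.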

Compound 4, half-maximal effective concentration: 16000 nM
The estimate for compound 4 lay 2.0-fold (0.30 log units) below the measured number, within the range that was stated.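

In this assay, chloro in place of (dimethylamino)methyl on a saturated chain carbon bound to a carbonyl carbon gives a 1.3-fold lower number from compound 3 to compound 4 (0.12 log units; within the scatter), so this exchange of a nitrogen-bearing group for a single halogen atom leaves the number within the scatter. Within the data shown here, compound 4 also provides a second measured number, which allows the first reading of a change at this position that is not limited by a floor. The steps of an at least 1.5-fold lower number from compound 1 to compound 4 (0.19 log units; that floor lies within the scatter) and an at least 1.5-fold lower number from compound 2 to compound 4 (0.19 log units; that floor lies within the scatter) remain floors, and the step between compound 1 and compound 2 cannot be read, because both of those compounds rest on the same limit: the limit of > 25000 nM in this assay, at which 2 of the 4 values shown sit.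

From the compounds shown here alone, what a carboxylic acid or a longer chain would do on this carbon remains open. Also open, going by these compounds, is whether a change to the shared core, rather than to the group on the carbonyl, would move the number beyond the scatter.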